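A few compounds are considered here, and "the series" means these few. Any claim that something is new, unique, unknown or untested is made for them only; others in the source may bear on it.

In a functional assay on A-375 cells (Homo sapiens) for antiproliferative activity, read by MTT assay, with a stated time of 24 h, tested at 0.14 ug/mL (on this read-out higher numbers stand for a stronger effect at the one concentration tested and lower numbers for a weaker effect), compound 1 `Cc1c(C(=O)Nc2c(F)cc(-c3cccc(F)c3)cc2F)nc2ccc(OC(F)(F)F)cc2c1O` gives 0.06%, compound 2 `Cc1c(C(=O)Nc2c(F)cc(-c3cccc(F)c3)cc2F)nc2ccc(C(F)(F)F)cc2c1O` gives 9.37% and compound 3 `COc1ccc2nc(C(=O)Nc3ccc(-c4ccccc4)cc3)c(C)c(O)c2c1` gives 3.05%. Compound 3 stands second highest of the three numbers; its gap to compound 1 and its gap to compound 2 are both within the scatter, so no order among the three is claimed. Among the measured compounds shown here, the single measured step, a number 9.3 percentage points higher from compound 1 to compound 2 (within the scatter), concerns a different substitution and does not bear on the change to compound 4 `Cc1c(C(=O)Nc2ccc(-c3ccccc3)cc2)nc2ccccc2c1O`, which is hydrogen in place of methoxy on an aromatic carbon. For the measured compounds named here, no measured step covers this change. With all three numbers within the scatter of one another, the expected step is a number 0.1 percentage points lower from compound 3 to compound 4 (within the scatter), none beyond the scatter. Compound 4 is therefore estimated at 3%, between 0% and 12%.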

Compound 4, a percentage reported as inhibition, at one concentration (the size of the read-out at that concentration, not a potency): 1.98%
Compound 4: the middle estimate sits 1 percentage points above what was measured, and the stated range covers the measured number.
By their numbers in this assay, from the lowest: compounds 1, 4, 3 and 2 (each within the scatter of the next).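

In this assay, among the compounds shown here, the first measured step at this position is a number 1.1 percentage points lower from compound 3 to compound 4 (within the scatter), so hydrogen in place of methoxy on this aromatic carbon gives no difference that can be told from the scatter. The position therefore tolerates the loss of methoxy on this read-out at the one concentration tested. No evidence on the cause of this result is available.

Going by these compounds, whether an amine, a carboxylic acid or a longer alkoxy chain at this position would give a step beyond the scatter remains open. Also open, on these data alone, is whether hydrogen in place of trifluoromethyl in compound 2 would read the same way.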